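The compounds below may be only part of what the source reports. "The series", "measured", "known", "first", "only" and "open" are said of these compounds alone.

For the measured compounds named here, compound 2 `Cc1ccc(-c2nnc(SCCCN3CCN(c4nc5ccccc5s4)CC3)o2)cc1` sits at the higher of the two numbers so far in a functional assay on HeLa cells (Homo sapiens) for inhibition, read by MTT assay, with a stated time of 72 h (a higher number here means a weaker inhibitor, a lower number a stronger inhibitor), where compound 2 gives 179000 nM. Going by the values given here, the nearest neighbour is compound 1 `Cc1ccc(-c2nnc(SCCCN3CCN(c4nc5ccccc5o4)CC3)o2)cc1`, which in this assay gives 133000 nM; the single measured step, a 1.3-fold higher number from compound 1 to compound 2 (0.13 log units; within the scatter), exchanges one fused bicyclic group on the piperazine nitrogen for another and lies within the scatter.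

The next compound, compound 3 `c1ccc(-c2nnc(SCCCN3CCN(c4nc5ccccc5s4)CC3)o2)cc1`, differs from compound 2 by hydrogen in place of methyl on an aromatic carbon. Among the compounds with values here, no measured step touches the methylphenyl end of the molecule, so the only step available, a 1.3-fold higher number from compound 1 to compound 2 (0.13 log units; within the scatter), speaks to a different part of the structure and gives no direct guide. With nothing in the data pointing to a shift at this end, a change of no more than the usual scatter is expected, and the step from compound 2 to compound 3 is estimated as a 1.1-fold higher number from compound 2 to compound 3 (0.05 log units; within the scatter). In this assay compound 3 is expected to give about 200000 nM, with a plausible range from 80000 nM to 500000 nM.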

Compound 3, half-maximal inhibitory concentration: 229000 nM
For compound 3 the middle estimate is 1.1-fold (0.06 log units) below the measured one, within the range that was stated.
By their numbers in this assay, from the lowest: compounds 1, 2 and 3 (each within the scatter of the next).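

For the compounds shown here, the 4-methylphenyl to phenyl exchange is the first measured change at this end of the molecule, on an aromatic carbon para to a large group, and in this assay it reads as a step within the scatter (a 1.3-fold higher number from compound 2 to compound 3 (0.11 log units; within the scatter)). Methyl and hydrogen at this position therefore cannot be told apart in this assay, so compound 2 and compound 3 give no sign that this position matters for the read-out, and the same holds for the exchange on the amine nitrogen in a ring (a 1.3-fold higher number from compound 1 to compound 2 (0.13 log units; within the scatter)). No supporting measurement accompanies this result, and nothing can be said about its origin.

From the compounds shown here alone, what a different group at this place would give, such as methoxy, chlorine or a carboxylic acid, stays open, since hydrogen and methyl span only a small part of what could stand there. Also open, going by these compounds, is what a longer chain in the linker would give, and whether any change to the shared core can bring the series to a much lower number in this assay, given that all three compounds lie within the scatter of their neighbours.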